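A few compounds are considered here, and "the series" means these few. Any claim that something is new, unique, unknown or untested is made for them only; others in the source may bear on it.

Three close relatives of one shared core have been tested in a functional assay on P388 cells (Mus musculus) for inhibition; on this read-out higher numbers stand for weaker inhibition and lower numbers for stronger inhibition. Compound 1 `O=C1CCCCC/C1=C\c1cccc(Cl)c1` gives 25700 nM, compound 2 `O=C1CCCCC/C1=C\c1ccc(Cl)cc1` gives 19100 nM, and compound 3 `O=C1CCCCC/C1=C\c1cccc(Br)c1` gives 24100 nM; all three sit within the scatter of one another, so no order among them can be read. The difference between the cores of compound 1 and compound 2 is not broken down here. Compound 3 arises from compound 1 by bromo in place of chloro on an aromatic carbon, and this step changed the read-out by a 1.1-fold lower number from compound 1 to compound 3 (0.03 log units; within the scatter). Compound 4 `O=C1CCCCC/C1=C\c1ccc(Br)cc1` arises from compound 2 by the same kind of change, (bromo in place of chloro on an aromatic carbon), differing only in that the place is para rather than meta to a group of 9 heavy atoms. Because the earlier step of a 1.1-fold lower number from compound 1 to compound 3 (0.03 log units; within the scatter) stayed within the scatter, a step of about a 1.1-fold lower number from compound 2 to compound 4 (0.03 log units; within the scatter) is expected here too. Compound 4 is therefore estimated at 18000 nM in this assay, between 9000 nM and 36000 nM.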

Compound 4, half-maximal inhibitory concentration: 16800 nM
Compound 4: the middle estimate sits 1.1-fold (0.03 log units) above what was measured; low and high end bracket the measured number.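

In this assay, bromo in place of chloro on an aromatic carbon gives a 1.1-fold lower number from compound 2 to compound 4 (0.06 log units; within the scatter), so on this core too the swap stays within the usual scatter of the measurement. Set side by side, the two cores respond to this change alike: the same change on two cores in this assay, a 1.1-fold lower number (0.03 log units; within the scatter) from compound 1 to compound 3 and a 1.1-fold lower number (0.06 log units; within the scatter) from compound 2 to compound 4, 1.1-fold (0.03 log units) apart, within the scatter of two such steps. This shows that the swap leaves the read-out about where it was on both cores, but neither step rises above the scatter, and it does not show how a change with a clear effect would carry from one core to another.

The compounds shown carry only chloro or bromo on the aromatic ring. Going by these compounds, what an amine, a carboxylic acid or a methoxy group would do there remains open, as does any change to the rest of the shared core.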